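The compounds below may be only part of what the source reports. "The series", "measured", "known", "first", "only" and "open" are said of these compounds alone.

Measured in a functional assay on HL-60 cells (Homo sapiens) for inhibition, read by MTT assay, with a stated time of 72 h; on this read-out lower numbers stand for stronger inhibition and higher numbers for weaker inhibition:
- compound 1 `CO[C@@H]1[C@H]2OC(=O)C[C@H]2O[C@@H]1[C@H](O)c1ccccc1`: 25000 nM
- compound 2 `CO[C@H](c1ccccc1)[C@H]1O[C@@H]2CC(=O)O[C@@H]2[C@H]1O`: 2960 nM
- compound 3 `CO[C@@H]1[C@H]2OC(=O)C[C@H]2O[C@@H]1[C@@H](OC)c1ccccc1`: 4360 nM

Compound 3, at 4360 nM, cannot be told apart from compound 2, at 2960 nM. Both numbers lie clearly under that of compound 1, at 25000 nM. Compound 4 `CO[C@@H]1[C@H]2OC(=O)C[C@H]2O[C@@H]1[C@H](OC)c1ccccc1` is the next case, and the comparison is with compound 3: the two compounds have the same atoms and bonds and differ only in configuration as drawn: 1 of 5 stereo elements differ; a stereocentre at a saturated chain carbon is drawn S in compound 3 and R in compound 4. No atoms leave or enter, and a stereocentre at a saturated chain carbon is drawn S in compound 3 and R in compound 4. Within the data shown here, no pair of measured compounds isolates a change of this kind, so the data give no direct measure of it and no firm direction. The expectation therefore stays anchored on compound 3 at 4360 nM. The estimate is a 1.1-fold higher number from compound 3 to compound 4 (0.06 log units; within the scatter), which means no expected change beyond the scatter, although a real shift either way remains possible. For compound 4 the estimated value is 5000 nM, with an expected range from 1500 nM to 20000 nM.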

Compound 4, half-maximal inhibitory concentration: 2210 nM
Beside the measured number, compound 4's estimate is 2.3-fold (0.35 log units) above it, within the range that was stated.
By their numbers in this assay, from the lowest: compounds 4, 2 and 3 (each within the scatter of the next); then compound 1.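

In this assay, the change of configuration at this saturated chain carbon gives a 2.0-fold lower number from compound 3 to compound 4 (0.30 log units; within the scatter), the first direct reading of such a change, and it stays within the scatter; the pair isolates configuration alone: the fact that compounds 3 and 4 differ only in the configuration as drawn

Methyl in place of hydrogen on an oxygen on a saturated carbon gives a 1.3-fold lower number from compound 2 to compound 4 (0.13 log units; within the scatter), whereas the same named change gives an 11-fold lower number from compound 1 to compound 4 (1.05 log units; beyond the scatter), which is large and beyond the scatter. Among these compounds, the two oxygens of compound 4 therefore do not read alike: only the step from compound 1 shows a clear change.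

The compounds shown carry only methyl or hydrogen on these oxygens, so it remains open how an ethyl or an acetyl group there would read. Also open, going by these compounds, is whether configuration at the chain carbon would read the same with a hydroxyl in place of the methoxy group.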